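The compounds below may be only part of what the source reports. "The series", "measured", "known", "first", "only" and "open" are said of these compounds alone.

- compound 1 `COc1ccc(CSc2nnc(-c3cc(OC)c(OC)c(OC)c3)n2-c2ccc(N(C)C)cc2)cc1` gives > 60000 nM (a limit)
- compound 2 `COc1ccc(C(=O)CSc2nnc(-c3cc(OC)c(OC)c(OC)c3)n2-c2ccc(N(C)C)cc2)cc1` gives 64000 nM (a number)
- compound 3 `COc1cc(-c2nnc(SCC(=O)c3ccc4ccccc4c3)n2-c2ccc(N(C)C)cc2)cc(OC)c1OC` gives > 60000 nM (a limit)

These results come from a functional assay on HT-29 cells (Homo sapiens) for inhibition, read by MTT assay, with a stated time of 48 h (a higher number here means a weaker inhibitor, a lower number a stronger inhibitor), with the limit of > 60000 nM in this assay, at which 2 of the 3 values shown sit, as the picture so far. Compound 3 sits at that end with > 60000 nM as its result, which is a limit and not a number.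

The next compound is compound 4 `COc1cc(-c2nnc(SCC(=O)Nc3ccc(Cl)cc3)n2-c2ccc(N(C)C)cc2)cc(OC)c1OC` and it keeps the shared core. It has (4-chlorophenyl)amino in place of naphthalen-2-yl on a carbonyl carbon, a change counted as (4-chlorophenyl)amino in place of naphthalen-2-yl on a carbonyl carbon here.

The measured steps that bear on this spot are a step that the limit leaves unreadable from compound 1 to compound 2 and a step that the two limits leave unreadable from compound 1 to compound 3 and a step that the limit leaves unreadable from compound 2 to compound 3 and none of them has a readable size. Among the compounds with values here, no measured compound carries (4-chlorophenyl)amino on that carbonyl carbon, so the measured steps set no size for this change.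

Within the data shown here, the only number nearby is compound 2 at 64000 nM in this series, so compound 4 is expected to stay a weak inhibitor. Compound 4 may again return only a limit.

The expected step is an at least 1.3-fold lower number from compound 3 to compound 4 (0.12 log units; that floor lies within the scatter) and no change beyond the usual scatter is expected.

The estimate for compound 4 is 45000 nM with an expected range from 12000 nM to 100000 nM in this test.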

Compound 4, half-maximal inhibitory concentration: > 60000 nM
Compound 4 gave a limit, no number (the forecaster's own chance of this, stated with the estimate: 50%); middle value at least 1.3-fold (0.12 log units) from the limit.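

Within the data shown here, compound 4 gives > 60000 nM in this assay, which is a limit and not a number, so no step linking it to compound 1, compound 2 or compound 3 can be read. The results now crowd at one end of the scale: the limit of > 60000 nM in this assay, at which 3 of the 4 values shown sit.

The compounds shown leave open whether any of these groups on the carbonyl carbon changes the strength of inhibition.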